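Dropping a Methyl Group: From Compound 3 to Compound 4

The source may report more compounds than this note shows. Statements on the series, on what has been measured and on what is new or still open speak of the compounds shown alone.

Compound 1 `O=C(NCc1ccc(CNS(=O)(=O)c2ccccc2)cc1)c1ccc([N+](=O)[O-])cc1` gives 100 nM
Compound 2 `O=C(NCc1ccc(CNS(=O)(=O)c2ccccc2)cc1)c1ccncc1` gives 10 nM
Compound 3 `Cc1ccc(S(=O)(=O)NCc2ccc(CNC(=O)c3ccccc3C)cc2)cc1` gives 100 nM

In an assay on MDA-MB-231 cells for binding affinity to C-X-C chemokine receptor type 4 (Homo sapiens), read by immunofluorescence and microscopy, with stated times of 10 min and 30 min (on this read-out higher numbers stand for an effect only at larger amounts of compound and lower numbers for an effect already at smaller amounts), compound 3 gives 100 nM, the same number at the digits shown as compound 1, and both give higher numbers than compound 2. Among the compounds with values here, the only measured step, a 10-fold lower number from compound 1 to compound 2 (1.00 log units; beyond the scatter), concerns the group on the carbonyl carbon and tells nothing about the far end of the molecule. Compound 4 `Cc1ccccc1C(=O)NCc1ccc(CNS(=O)(=O)c2ccccc2)cc1` differs from compound 3 at that far end: hydrogen in place of methyl on an aromatic carbon. Within the data shown here, no measured pair shows this kind of change, so nothing beyond the scatter is expected in no change at the digits printed from compound 3 to compound 4 (within the scatter). Compound 4 is therefore estimated at 100 nM, with a range from 30 nM to 300 nM.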

Compound 4, effective concentration (reported as EC, without a stated level of effect): 1 nM
Compound 4: middle estimate off by 100-fold (2.00 log units), on the high side, outside the stated range (below it).
By their numbers in this assay, from the lowest: compound 4; then compound 2; then compounds 1 and 3 (each within the scatter of the next).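

In this assay the far end of the molecule proves to count: the change from 4-methylphenyl to phenyl gives a 100-fold lower number from compound 3 to compound 4 (2.00 log units; beyond the scatter) and so is not a silent edit. With phenyl at that end, 2-methylphenyl on the carbonyl carbon gives a 10-fold lower number from compound 2 to compound 4 (1.00 log units; beyond the scatter) and also a 100-fold lower number from compound 1 to compound 4 (2.00 log units; beyond the scatter) in comparison with the other two groups there. Nothing measured here explains the size of these steps.

From the compounds shown here alone, whether an ethyl group, a chlorine atom or a methoxy group at the place of that methyl would read like compound 3 or like compound 4 stays open. So does the result of pairing the unsubstituted phenyl with other groups on the carbonyl carbon, such as a 3-pyridyl ring.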